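The source may hold more compounds than are shown below. What is called first, only, known or untested is meant among the compounds shown, and "the series" means these compounds.

Four compounds are compared here. Compound 1 `Cc1ccccc1-c1cccc(COc2ccc(S(=O)(=O)CC(=O)O)cc2)c1` and compound 2 `O=C(O)CS(=O)(=O)c1ccc(OCc2cccc(-c3ccccc3Cl)c2)cc1` are close relatives. In a functional assay on CHO cells for agonist activity at Free fatty acid receptor 1 (Homo sapiens), read by FLIPR and calcium flux (a higher number here means that more compound is needed for the effect, a lower number that less compound is needed), compound 1 gives 46.8 nM, and compound 2 gives 28.8 nM. The change between them is chloro in place of methyl on an aromatic carbon, and it made a step of a 1.6-fold lower number from compound 1 to compound 2 (0.21 log units; within the scatter). Compound 3 `Cc1ccc(-c2c(C)noc2C)cc1COc1ccc(S(=O)(=O)CC(=O)O)cc1` rests on another core; the difference between the two cores is not broken down here. In this assay compound 3 gives 427 nM. Compound 4 `Cc1noc(C)c1-c1ccc(Cl)c(COc2ccc(S(=O)(=O)CC(=O)O)cc2)c1` differs from compound 3 by chloro in place of methyl on an aromatic carbon, the same kind of change as from compound 1 to compound 2, though here the place is also para to a 3,5-dimethyl-1,2-oxazol-4-yl group. A step of similar size is expected, a 1.5-fold lower number from compound 3 to compound 4 (0.18 log units; within the scatter). That expectation rests on the earlier step of a 1.6-fold lower number from compound 1 to compound 2 (0.21 log units; within the scatter). Compound 4 is therefore estimated at 280 nM in this assay, most likely between 120 nM and 650 nM.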

Compound 4, half-maximal effective concentration: 234 nM
Estimate against measurement, compound 4: 1.2-fold (0.08 log units) above; the range from low to high includes it.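

In this assay, chloro in place of methyl gives a 1.8-fold lower number from compound 3 to compound 4 (0.26 log units; within the scatter), and this step matches the one seen on the other core: the same change on two cores in this assay, a 1.6-fold lower number (0.21 log units; within the scatter) from compound 1 to compound 2 and a 1.8-fold lower number (0.26 log units; within the scatter) from compound 3 to compound 4, 1.1-fold (0.05 log units) apart, within the scatter of two such steps. The change therefore carries over between these two cores without a visible shift in the size of its step. It does not show that chloro and methyl truly differ at this place, as each step lies within the scatter, and two cores cannot speak for the whole series.

The compounds shown leave open how a fluoro or a methoxy group would behave at this place. They also leave open whether the same small step would hold on a third core.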